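The compounds below may be only part of what the source reports. "The series", "measured", "known", "first", "only" and "open" are said of these compounds alone.

Working notes on the series. The set so far holds three measured compounds: compound 1 `O=c1cc(-n2cc(COc3ccccc3O)nn2)c2cc(Br)ccc2o1`, compound 2 `COc1ccc2oc(=O)cc(-n3cc(COc4ccc(F)cc4)nn3)c2c1` and compound 3 `O=[N+]([O-])c1cnc2ccc(Br)cc2c1-n1cc(CSc2ccccc2)nn1`. In a functional assay on MCF7 cells (Homo sapiens) for antiproliferative activity, read by MTT assay, with a stated time of 48 h (on this read-out lower numbers stand for stronger inhibition and higher numbers for weaker inhibition), compound 1 gives 24800 nM, compound 2 gives 8560 nM and compound 3 gives 22700 nM. Compound 3 stands second highest of the three numbers; its nearest neighbour is compound 1, whose number lies within the scatter of it, and its furthest is compound 2, whose number sits lower by a gap beyond the scatter. Among the compounds with values here, no pair of measured compounds differs in a single place, so no measured step is available.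

Compound 4 `O=[N+]([O-])c1cnc2ccc(Br)cc2c1-n1cc(COc2ccccc2)nn1` is not yet measured. It differs from compound 3 by one change: phenoxy in place of phenylsulfanyl on a saturated chain carbon bound to an aromatic carbon. Compound 1 also carries a phenoxymethyl on its own core and its value in this assay sits close to that of compound 3, which is the only indirect hint on this change. The step from compound 3 to compound 4 is expected to be small, a 1.1-fold lower number from compound 3 to compound 4 (0.05 log units; within the scatter), with no clear direction beyond the scatter. Compound 4 is therefore estimated at 20000 nM, with a range from 7000 nM to 55000 nM.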

Compound 4, half-maximal inhibitory concentration: 7690 nM
Compound 4: middle estimate off by 2.6-fold (0.42 log units), on the high side, within the range that was stated.
By their numbers in this assay, from the lowest: compounds 4 and 2 (each within the scatter of the next); then compounds 3 and 1 (each within the scatter of the next).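

Working notes, continued. In this assay the place on a saturated chain carbon bound to an aromatic carbon proves sensitive to the linking atom: phenoxy in place of phenylsulfanyl gives a 3.0-fold lower number from compound 3 to compound 4 (0.47 log units; beyond the scatter) and the step is modest but beyond the scatter. The two groups match in heavy-atom count and in donors and acceptors as counted, so on this core the exchange of sulfur for oxygen alone is enough to shift the number. Nothing on hand bears on what lies behind this step.

On these data alone, the step rests on a single pair on one core, so whether it carries over to the cores of compound 1 and compound 2 stays open. As far as these compounds go, how an anilino group or a longer chain such as phenylethoxy would read at this place also stays open.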